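From a Carboxy to a Hydroxy Amide in Paw Edema

A few compounds are considered here, and "the series" means these few. Any claim that something is new, unique, unknown or untested is made for them only; others in the source may bear on it.

Compound 3 `COc1ccc(-n2nc(C(=O)Nc3ccc(C(=O)O)cc3)nc2-c2cc(OC)c(OC)c(OC)c2)cc1` stands highest of the three measured compounds in a functional assay on the whole organism for inhibition, with Rattus norvegicus as the target, read by paw edema, with stated times of 30 min and 4 h, at a dose of 0.28 mmol/kg by the oral route (on this read-out higher numbers stand for more inhibition at the one dose given (going by the name of the read-out) and lower numbers for less inhibition), where compound 3 gives 69%. In this assay compound 1 `CNC(=O)c1nc(-c2cc(OC)c(OC)c(OC)c2)n(-c2ccc(OC)cc2)n1` gives 65%, and compound 2 `COc1ccc(-n2nc(C(=O)Nc3ccccc3C)nc2-c2cc(OC)c(OC)c(OC)c2)cc1` gives 46%. The step of a number 4 percentage points higher from compound 1 to compound 3 (within the scatter) lies within the scatter, so compound 3 and compound 1 cannot be set in order; the step of a number 23 percentage points higher from compound 2 to compound 3 (beyond the scatter) lies beyond it, as does a number 19 percentage points lower from compound 1 to compound 2 (beyond the scatter).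

Compound 4 `COc1ccc(-n2nc(C(=O)Nc3ccc(O)cc3)nc2-c2cc(OC)c(OC)c(OC)c2)cc1` differs from compound 3 by hydroxy in place of carboxy on an aromatic carbon. Among the measured compounds shown here, no measured step alters a group on that aromatic ring. For the measured compounds named here, the steps that bear on it are those at the amide-type nitrogen, a number 23 percentage points higher from compound 2 to compound 3 (beyond the scatter) and a number 4 percentage points higher from compound 1 to compound 3 (within the scatter), which show the aryl amides spanning a modest range around the methyl amide. Since the 4-hydroxyphenyl group keeps one hydrogen-bond donor and one acceptor, a step of a number 9 percentage points lower from compound 3 to compound 4 (within the scatter) is expected for compound 4, within the scatter or slightly downward. Compound 4 is therefore estimated at 60%, with a range from 42% to 76%.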

Compound 4, a percentage reported as inhibition, in the whole organism at one dose (the size of the read-out at that dose, not a potency): 37%
For compound 4 the middle estimate is 23 percentage points above the measured one; the measured number lies below the stated range.
By their numbers in this assay, from the lowest: compounds 4 and 2 (each within the scatter of the next); then compounds 1 and 3 (each within the scatter of the next).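

With hydroxy in place of carboxy on the aromatic carbon, this assay gives a number 32 percentage points lower from compound 3 to compound 4 (beyond the scatter) and so shows that the group on this ring, and not only the choice of aryl over methyl on the amide-type nitrogen, bears on the inhibition. The 4-hydroxyphenyl amide also gives a number 28 percentage points lower from compound 1 to compound 4 (beyond the scatter) against the methyl amide, a gap the 4-carboxyphenyl amide did not show, while the comparison with the 2-methylphenyl amide gives a number 9 percentage points lower from compound 2 to compound 4 (within the scatter) and sets no order between those two. Carboxy and hydroxy have matching hydrogen-bond donor and acceptor counts, so those counts do not separate them, and no measurement at hand explains the step.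

The compounds shown leave open what a methyl ester, a primary amide or an amine would give on this carbon. They also leave open whether carboxy would hold its level elsewhere on the ring.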